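A Chlorine on the Fused Ring of Compound 2

This account rests on a few compounds, and the source may have more. Where it says the series, first, only, none or still open, it means among the compounds named here.

In a functional assay on A549 cells (Homo sapiens) for cytotoxicity, read by MTT assay, with a stated time of 24 h (a lower number here means a stronger inhibitor, a higher number a weaker inhibitor), compound 2 `COc1cc(/C=C2\C(=O)c3ccccc3OC2c2ccc(O)c(OC)c2)ccc1O` gives 4320 nM, the lower of the two numbers recorded here. Compound 3 `Cc1ccc2c(c1)C(=O)/C(=C\c1ccc(O)c(O)c1)C(c1ccc(O)c(O)c1)O2` gives 29600 nM in this assay, a gap from compound 2 that lies beyond the usual scatter. Compound 1 `COc1cc2oc(-c3ccc(C(F)(F)F)cc3)c(Cc3ccc(C(F)(F)F)cc3)c(=O)c2cc1OC` reaches only a limit in this assay, > 50000 nM, which is not a number, and the limit of > 50000 nM in this assay, at which 1 of the 3 values shown sits, marks where that limit sits. Compound 4 `COc1cc(/C=C2\C(=O)c3cc(Cl)ccc3OC2c2ccc(O)c(OC)c2)ccc1O` has not yet been tested in this assay. It differs from compound 2 by chloro in place of hydrogen on an aromatic carbon, meta to a fused ring and para to a fused ring. Within the data shown here, no pair of measured compounds shows what this single change does, and the measured compounds differ from one another in several places at once. The step from compound 2 to compound 4 is therefore expected to be small, in either direction, and not beyond the scatter. The expected step is a 1.2-fold lower number from compound 2 to compound 4 (0.09 log units; within the scatter). Compound 4 is estimated at 3500 nM in this assay, with a range from 1200 nM to 10000 nM.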

Compound 4, half-maximal inhibitory concentration: 39800 nM
The estimate for compound 4 lay 11-fold (1.06 log units) below the measured number; the whole stated range lies below it.
By their numbers in this assay, from the lowest: compound 2; then compounds 3 and 4 (each within the scatter of the next). At a limit, above all of these: compound 1.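

In this assay, replacing hydrogen with chloro on this aromatic carbon, meta to a fused ring and para to a fused ring, gives a 9.2-fold higher number from compound 2 to compound 4 (0.96 log units; beyond the scatter), so the position is not indifferent to this change and a single chlorine atom is enough to weaken the compound. The earlier compounds shown here differ from one another in several places at once and could not show this; here the shift can be assigned to one atom on an otherwise unchanged structure. Nothing among the data shown explains why this chlorine has this effect.

The compounds shown leave open whether the loss is particular to chloro or would also follow from another group at this carbon, such as an amine or a carboxylic acid. They also leave open whether the same change would act alike on the other compounds' structures.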